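A few compounds are considered here, and "the series" means these few. Any claim that something is new, unique, unknown or untested is made for them only; others in the source may bear on it.

Measured compounds:
Compound 1, `COc1ccc(/C=C/c2cc(OC)cc(OC)c2/C=C/C(=O)c2cccc(OC)c2)cc1`: 11.6 ug/mL
Compound 2, `CCCC(C)Oc1ccc(C(=O)/C=C/c2c(/C=C/c3ccc(OC)cc3)cc(OC)cc2OC)cc1`: 11.1 ug/mL
Compound 3, `COc1ccc(/C=C/c2cc(OC)cc(OC)c2/C=C/C(=O)c2ccc(F)cc2)cc1`: 12.2 ug/mL

In a functional assay on HepG2 cells (Homo sapiens) for antiproliferative activity, read by MTT assay, with a stated time of 48 h (a higher number here means a weaker inhibitor, a lower number a stronger inhibitor), compound 1 gives 11.6 ug/mL, and the two other values sit so close to it that all three lie within the scatter of one another. The step of a 1.0-fold lower number from compound 1 to compound 2 (0.02 log units; within the scatter) and the step of a 1.1-fold higher number from compound 1 to compound 3 (0.02 log units; within the scatter) both replace the ring on the carbonyl carbon, and neither moves the number beyond the scatter; the step of a 1.1-fold higher number from compound 2 to compound 3 (0.04 log units; within the scatter) between the two variants is likewise flat.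

Compound 4, `COc1ccc(/C=C/c2cc(OC)cc(OC)c2/C=C/C(=O)c2ccc(C)cc2C)cc1`, differs from compound 1 in the same place: 2,4-dimethylphenyl in place of 3-methoxyphenyl on a carbonyl carbon. The two measured steps that change this very ring, from compound 1 to compound 2 and from compound 1 to compound 3, are the ones that bear on it, and both were flat. On that basis no step beyond the scatter is expected in this assay for compound 4; the step of a 1.0-fold lower number from compound 1 to compound 4 (0.00 log units; within the scatter) is the expected outcome. The estimated value for compound 4 is therefore 11.5 ug/mL, with an expected range from 6 ug/mL to 23 ug/mL.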

Compound 4, half-maximal inhibitory concentration: 0.9 ug/mL
The estimate for compound 4 lay 13-fold (1.11 log units) above the measured number, outside the stated range (below it).
By their numbers in this assay, from the lowest: compound 4; then compounds 2, 1 and 3 (each within the scatter of the next).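

In this assay, the ring on the carbonyl carbon proves far from indifferent: 2,4-dimethylphenyl gives a 13-fold lower number from compound 1 to compound 4 (1.11 log units; beyond the scatter) and a 14-fold lower number from compound 3 to compound 4 (1.13 log units; beyond the scatter) and a 12-fold lower number from compound 2 to compound 4 (1.09 log units; beyond the scatter) while the earlier swaps among 3-methoxyphenyl, 4-fluorophenyl and 4-(1-methylbutoxy)phenyl all stayed within the scatter. The flat picture from the first three compounds therefore held only for those rings and not for the position as a whole, and the three new steps are closely similar whichever of them is the starting ring. The change from compound 1 keeps the count of heavy atoms and replaces a group with one hydrogen-bond acceptor by one with none, yet nothing available here links this step to any measured property or explains why the number falls so far.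

The compounds shown leave open whether a single methyl group on this ring would be enough or both methyl groups are needed. They also leave open whether a longer chain such as ethyl, or an amine or a carboxylic acid, on the same ring would keep the number this low.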